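A few compounds are considered here, and "the series" means these few. Any claim that something is new, unique, unknown or untested is made for them only; others in the source may bear on it.

Measured so far in a functional assay on CHO-K1 cells for antagonist activity at adenosine receptor A1 (Homo sapiens), read by a beta-galactosidase reporter and cAMP accumulation, with stated times of 15 min and 6 h; a higher number here means a weaker inhibitor, a lower number a stronger inhibitor:
compound 1 `COc1ccccc1Cc1cc2c(N)nc(-c3ccc(C)o3)nc2s1` gives 122 nM
compound 2 `N#Cc1ccc(-c2nc(N)c3cc(Cc4ccccc4)sc3n2)o1` gives 3160 nM
compound 3 `Nc1nc(-c2ccc(C(F)F)o2)nc2sc(Cc3ccccc3)cc12` gives 3000 nM

Compound 3 stands second highest of the three numbers in this assay. Its nearest neighbour is compound 2, whose value lies within the scatter of compound 3, so no order between them can be read. Compound 1 lies furthest away, beyond the scatter, with the lower number of the set. Among the compounds with values here, the one measured step that is a single change, from compound 2 to compound 3, was a 1.1-fold lower number from compound 2 to compound 3 (0.02 log units; within the scatter), a difluoromethyl replacing a cyano on the furan.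

Compound 4 `COc1ccccc1Cc1cc2c(N)nc(-c3ccc(C(F)F)o3)nc2s1` differs from compound 3 by methoxy in place of hydrogen on an aromatic carbon. Within the data shown here, no measured step isolates this change: compound 1 carries the same methoxy but also a methyl in place of the difluoromethyl, so its distance from compound 3 mixes two changes. With that caveat, compound 4 is expected to move toward compound 1 by a 5.0-fold lower number from compound 3 to compound 4 (0.70 log units; beyond the scatter), and compound 4 is estimated at 600 nM with a range from 150 nM to 2500 nM.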

Compound 4, inhibition constant: 516 nM
Beside the measured number, compound 4's estimate is 1.2-fold (0.07 log units) above it; the measured number falls inside the stated range.
By their numbers in this assay, from the lowest: compound 1; then compound 4; then compounds 3 and 2 (each within the scatter of the next).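

In this assay, the change from benzyl to 2-methoxybenzyl now stands as a single step with the difluoromethyl held fixed, and it lowers the number beyond the scatter (a 5.8-fold lower number from compound 3 to compound 4 (0.76 log units; beyond the scatter)). This step isolates methoxy on the aromatic carbon ortho to a large group. Compound 1 alone could not separate this change from the change of difluoromethyl to methyl. With the 2-methoxybenzyl held fixed, the other change can also be read alone: difluoromethyl in place of methyl raises the number beyond the scatter (a 4.2-fold higher number from compound 1 to compound 4 (0.63 log units; beyond the scatter)), and nothing available explains either step.

The compounds shown leave open whether an ethoxy, a hydroxyl or a chlorine at the same place would act as methoxy does. They also leave open whether methoxy would give a similar step alongside the nitrile of compound 2.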